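Compound 4: 2-methoxyphenyl in place of 3-ethylphenyl

A few compounds are considered here, and "the series" means these few. Any claim that something is new, unique, unknown or untested is made for them only; others in the source may bear on it.

In a functional assay on the whole organism for inhibition, with Rattus norvegicus as the target (on this read-out lower numbers stand for an effect already at smaller amounts and higher numbers for an effect only at larger amounts of compound), compound 1 `Cc1cccc(CC(C)(Oc2ccc(C(C)C)cc2)C(=O)O)c1` gives < 1 mg/kg, which is a limit of the assay and not a number. Compound 2 `CCc1ccccc1CC(C)(Oc1ccc(C(C)C)cc1)C(=O)O` gives 5 mg/kg. Compound 3 `CCc1cccc(CC(C)(Oc2ccc(C(C)C)cc2)C(=O)O)c1` gives 0.5 mg/kg, the lower of the two actual numbers in the series.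

Compound 4 `COc1ccccc1CC(C)(Oc1ccc(C(C)C)cc1)C(=O)O` carries 2-methoxyphenyl in place of 3-ethylphenyl on a saturated chain carbon, two bonds along the chain from a carbonyl carbon and an oxygen on an aromatic ring.

The closest measured change is a 10-fold lower number from compound 2 to compound 3 (1.00 log units; beyond the scatter), with 3-ethylphenyl in place of 2-ethylphenyl. Also relevant is an at least 5.0-fold higher number from compound 1 to compound 2 (0.69 log units; beyond the scatter), with 2-ethylphenyl in place of 3-methylphenyl. Within the data shown here, both steps set compound 2, the only measured 2-substituted phenyl compound, at the high end, though no methoxy compound has been measured and the carry-over is uncertain.

A rise in this assay is therefore expected, somewhat smaller than the ethyl step. The estimated step is a 5.0-fold higher number from compound 3 to compound 4 (0.70 log units; beyond the scatter). Compound 4 is estimated at 2.5 mg/kg, with an expected range from 0.7 mg/kg to 9 mg/kg.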

Compound 4, dose for half-maximal effect: > 10 mg/kg
Compound 4 was reported as a limit (the forecaster's own chance of this, stated with the estimate: 10%); middle value at least 4.0-fold (0.60 log units) away from the limit.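

In this assay compound 4 gives > 10 mg/kg, which is a limit of the assay and not a number. Even so, the change at this place on the saturated chain carbon is large against the 3-ethylphenyl group, as an at least 20-fold higher number from compound 3 to compound 4 (1.30 log units; beyond the scatter), and clear against the 3-methylphenyl group, as an at least 10-fold higher number from compound 1 to compound 4 (1.00 log units; beyond the scatter), so among the four compounds shown both 2-substituted phenyl groups sit at the high end of the read-out. Methoxy in place of ethyl on an aromatic carbon stays unranked, since an at least 2.0-fold higher number from compound 2 to compound 4 (0.30 log units; that floor lies within the scatter) gives only a floor, and that floor lies within the scatter.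

A 3-methoxyphenyl group at this place would separate the effect of the methoxy group from that of its ring position, which the step from compound 3 changes together. From the compounds shown here alone, how far compound 4 actually lies from compound 2 also remains open.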